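The compounds below may be only part of what the source reports. "The series", "measured", "known", "first", "only" and "open" are said of these compounds alone.

The measured compounds:
Compound 1 `COc1cc(OC)c2c(=O)cc(/C=C/c3ccc([N+](=O)[O-])cc3)oc2c1`, which in a functional assay on A549 cells (Homo sapiens) for antiproliferative activity, read by MTT assay, with a stated time of 12 h (on this read-out higher numbers stand for weaker inhibition and lower numbers for stronger inhibition), gives 19700 nM.
Compound 2 `COc1cc(OC)c2c(=O)cc(/C=C/c3ccc(Cl)cc3)oc2c1`, which in this assay gives > 40000 nM, a limit of the assay and not a number.

Compound 2 thus stands at the edge of what this assay reports: its value is a limit, as noted in the limit of > 40000 nM in this assay, at which 1 of the 2 values shown sits, and nothing more can be said of where it sits. Among the compounds with values here, the one measured step, chloro in place of nitro on an aromatic carbon, reads an at least 2.0-fold higher number from compound 1 to compound 2 (0.30 log units; that floor lies within the scatter), and its floor lies within the scatter.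

Compound 3 `COc1ccc(/C=C/c2cc(=O)c3c(OC)cc(OC)cc3o2)cc1` differs from compound 2 in one place: methoxy in place of chloro on an aromatic carbon. Within the data shown here, no measured step swaps chloro for methoxy, so the step from compound 1 to compound 2 is the only one that touches this position, and it does not reach beyond the scatter with certainty. With compound 2 at a limit, the size of the step to compound 3 cannot be anchored. The estimate for compound 3 in this assay is 45000 nM, expected between 15000 nM and 150000 nM. That expectation amounts to a step that the limit leaves unreadable from compound 2 to compound 3, with a real chance that compound 3 is again reported only as a limit.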

Compound 3, half-maximal inhibitory concentration: > 40000 nM
Compound 3: a limit, no number (the forecaster's own chance of this, stated with the estimate: 60%); the middle value is on the limit's open side.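

Compound 3 is reported in this assay as > 40000 nM, which is a limit and not a number. Methoxy thus joins chloro in giving no number at this position, so among the three groups shown only nitro yields a readable value, and the change from nitro to methoxy reads an at least 2.0-fold higher number from compound 1 to compound 3 (0.30 log units; that floor lies within the scatter). The step from chloro to methoxy itself cannot be read, since both compounds sit at the same limit: the limit of > 40000 nM in this assay, at which 2 of the 3 values shown sit.

The compounds shown leave open whether a measurable value at this position belongs to nitro alone, or whether an amine, a carboxylic acid or a nitrile on the same aromatic carbon would also give one. They also leave open how far compound 2 and compound 3 lie from each other, and whether either truly differs from compound 1 by more than the scatter of this kind of measurement.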